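The source may report more compounds than this note shows. Statements on the series, on what has been measured and on what is new or still open speak of the compounds shown alone.

Measured compounds:
Compound 1, `Cc1nc2sc(-c3ccccc3)nc2c(=O)[nH]1`, in an assay on CHO cells for displacement of a labelled ligand from adenosine receptor A3 (Homo sapiens), read by scintillation counting, with a stated time of 120 min (on this read-out lower numbers stand for stronger inhibition and higher numbers for weaker inhibition), gives 85 nM.
Compound 2, `COc1cccc(Nc2nc3c(=O)[nH]c(C)nc3s2)c1`, in this assay gives 113 nM.

Of the two numbers, compound 2 holds the higher one, yet the gap to compound 1 lies within the scatter, so the two are not separable. Compound 3, `Cc1cccc(Nc2nc3c(=O)[nH]c(C)nc3s2)c1`, differs from compound 2 by methyl in place of methoxy on an aromatic carbon. Going by the values given here, no measured pair shows this change, so no step size is known from the series; the expectation is none beyond the scatter, in either direction, for the step of a 1.1-fold higher number from compound 2 to compound 3 (0.03 log units; within the scatter). Compound 3 is therefore estimated at 120 nM in this assay, with a range from 50 nM to 300 nM.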

Compound 3, inhibition constant: 450 nM
Beside the measured number, compound 3's estimate is 3.8-fold (0.57 log units) below it; measured number above the stated range.
By their numbers in this assay, from the lowest: compounds 1 and 2 (each within the scatter of the next); then compound 3.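

Methyl in place of methoxy on this aromatic carbon gives a 4.0-fold higher number from compound 2 to compound 3 (0.60 log units; beyond the scatter) in this assay and is the first single-place step in the series, showing that this place, meta to a large group, does respond to the choice of group. With a single pair, the size of the step rests on this one change. No measurement on hand accounts for it.

Open, from the compounds shown here alone, is whether the methoxy group favours the lower number or the methyl group disfavours it. An unsubstituted ring, an ethoxy group or an amine at this place would help separate the two readings.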